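A Larger Group on the Amide Nitrogen

The source may report more compounds than this note shows. Statements on the series, on what has been measured and on what is new or still open speak of the compounds shown alone.

- compound 1 `CON=C1CCC(N(c2cc(C#CC(C)(C)C)sc2C(=O)O)C(=O)[C@H]2CC[C@H](C)CC2)CC1` gives 0.07
- compound 2 `CC(C)(C)C#Cc1cc(N(CCO)C(=O)[C@H]2CC[C@H](C)CC2)c(C(=O)O)s1` gives "not determined" (no result reported)

Compound 2 has no single number in an ADME assay for protein binding, using equilibrium dialysis, at pH 7.4, tested at 2 uM (on this read-out higher numbers stand for a larger free fraction and lower numbers for a smaller free fraction), so it has no place on this scale. Compound 3 `C[C@@H](CCOc1cccnc1)N(c1cc(C#CC(C)(C)C)sc1C(=O)O)C(=O)[C@H]1CC[C@H](C)CC1` has not been measured yet. Its structure differs from that of compound 2 as follows 1-methyl-3-((pyridin-3-yl)oxy)propyl in place of 2-hydroxyethyl on an amide-type nitrogen with 1-methyl-3-((pyridin-3-yl)oxy)propyl in place of 2-hydroxyethyl on an amide-type nitrogen. Within the data shown here, no measured step shows what such a change does. Among the measured compounds shown here, the only guide is compound 1 at 0.07 and no shift beyond the usual scatter from that value is expected. Compound 3 is expected to read 0.05 within an estimated range of 0.02 to 0.12 in this measurement.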

Compound 3, unbound fraction: 0.02
For compound 3 the middle estimate is 2.5-fold (0.40 log units) above the measured one, and the stated range covers the measured number.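

In this assay, the group on the amide-type nitrogen clearly affects the read-out: replacing a group with a six-membered non-aromatic ring of carbon only by 1-methyl-3-((pyridin-3-yl)oxy)propyl gives a 3.5-fold lower number from compound 1 to compound 3 (0.54 log units; beyond the scatter) and leaves less of the compound free. The two groups differ in several features at once, so this step cannot assign the change to any one of them. No measurement here explains the step. From the compounds shown here alone, it remains open how a group ending in an amine or a carboxylic acid on this nitrogen would read, and whether a longer chain would shift the number further.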